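Branched alkyl replaces acetylcyclohexylmethyl on the benzimidazole-like nitrogen

A few compounds are considered here, and "the series" means these few. Any claim that something is new, unique, unknown or untested is made for them only; others in the source may bear on it.

Measured compounds:
Compound 1 `CC(=O)N1CCC(n2c(-c3ccc(OCc4c(-c5c(Cl)cccc5Cl)noc4C(C)C)cc3)nc3ccc(C(=O)O)cc32)CC1` gives > 10000 nM in an assay on HEK-293T cells for antagonist activity at vitamin D3 receptor (Homo sapiens), read by a luciferase reporter, with a stated time of 24 h (a higher number here means a weaker inhibitor, a lower number a stronger inhibitor), a limit of the assay.
Compound 2 `CC(C)c1onc(-c2c(Cl)cccc2Cl)c1COc1ccc(-c2nc3ccc(C(=O)O)cc3n2C2CCC2)cc1` gives 1100 nM in this assay.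
Compound 3 `CC(=O)C1CCC(Cn2c(-c3ccc(OCc4c(-c5c(Cl)cccc5Cl)noc4C(C)C)cc3)nc3ccc(C(=O)O)cc32)CC1` gives > 10000 nM in this assay, a limit of the assay.

Compound 3 therefore stands at the limit of > 10000 nM in this assay, at which 2 of the 3 values shown sit, with no number of its own; it sits at the weak end of what the three compounds show. Compound 4 `CCCC(CCC)n1c(-c2ccc(OCc3c(-c4c(Cl)cccc4Cl)noc3C(C)C)cc2)nc2ccc(C(=O)O)cc21` carries the change (1-propylbutyl in place of (4-acetylcyclohexyl)methyl on an aromatic nitrogen). The step that bears most directly on it is an at least 9.0-fold higher number from compound 2 to compound 3 (0.95 log units; beyond the scatter), which shows that a small ring on that nitrogen gives a number while the (4-acetylcyclohexyl)methyl group only reaches the limit; an at least 9.0-fold lower number from compound 1 to compound 2 (0.95 log units; beyond the scatter) points the same way for 1-acetylpiperidin-4-yl. A 1-propylbutyl group lacks the acetyl of both weak compounds and, like cyclobutyl, is branched at the point of attachment, so compound 4 is expected to move back toward compound 2, giving an expected step of an at least 4.0-fold lower number from compound 3 to compound 4 (0.60 log units; beyond the scatter) toward a lower number. Compound 4 is thus estimated at 2500 nM, with a range from 700 nM to 10000 nM.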

Compound 4, half-maximal inhibitory concentration: > 10000 nM
Compound 4: a limit, no number; the forecaster's own chance of this, stated with the estimate: 30%; middle value at least 4.0-fold (0.60 log units) from the limit.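

In this assay compound 4 gives > 10000 nM, a limit of the assay. With 1-propylbutyl in place of cyclobutyl the result is an at least 9.0-fold higher number from compound 2 to compound 4 (0.95 log units; beyond the scatter), so neither the lack of an acetyl group nor branching at the point of attachment is enough on its own to give a number at this nitrogen. The steps from compound 1 and from compound 3 to compound 4 cannot be read, and compound 2 alone now stands off the limit: the limit of > 10000 nM in this assay, at which 3 of the 4 values shown sit.

The compounds shown leave open whether a shorter branched chain such as isopropyl, or another small ring such as cyclopentyl, would also give a number at this nitrogen. They also leave open how far compound 1, compound 3 and compound 4 differ from one another beyond the limit.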